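Methyl Swapped for Chlorine on the Phenoxy Group

The source may hold more compounds than are shown below. What is called first, only, known or untested is meant among the compounds shown, and "the series" means these compounds.

Four compounds built on one shared core are followed in a functional assay on HepG2 cells (Homo sapiens) for antiproliferative activity, read by MTT assay, with a stated time of 72 h; on this read-out higher numbers stand for weaker inhibition and lower numbers for stronger inhibition. Compound 1 `NC1=NC2(CCOCC2)N(OCCCOc2ccc(Cl)c(Cl)c2)C(N)=N1` carries a chlorinated phenoxy group at the end of its chain and gives 380 nM in this assay. Compound 2 `NC1=NC2(CCOCC2)N(OCCCOc2ccc(F)cc2)C(N)=N1`, with a fluorinated phenoxy group in the same place, gives "not determined" (no result reported) in this assay. Within the data shown here, compound 3 `Cc1ccc(OCCCON2C(N)=NC(N)=NC23CCOCC3)cc1`, which carries a 4-methylphenoxy group, also gives "not determined" (no result reported) in this assay, so compound 3 stands without a number of its own, and the single number in the set belongs to compound 1. Compound 4 `NC1=NC2(CCOCC2)N(OCCCOc2ccccc2Cl)C(N)=N1` is one step from compound 3: 2-chlorophenyl in place of 4-methylphenyl on an oxygen on a saturated carbon. Among the measured compounds shown here, with no number for compound 3, no step from it can be computed and no direction can be read off; the one anchor is compound 1, and a step from the chlorinated analogue to compound 4 would likely fall near or a little beyond the scatter, toward weaker inhibition, since compound 1 gives 380 nM. Compound 4 is expected to give about 900 nM in this assay, within an estimated range from 250 nM to 4000 nM.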

Compound 4, half-maximal inhibitory concentration: 1750 nM
Compound 4: middle estimate off by 1.9-fold (0.29 log units), on the low side, within the range that was stated.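

In this assay, putting 2-chlorophenyl in place of 3,4-dichlorophenyl on an oxygen on a saturated carbon gives a 4.6-fold higher number from compound 1 to compound 4 (0.66 log units; beyond the scatter), a shift toward weaker inhibition that lies beyond the usual scatter, so the group at this place does affect the read-out. Steps involving compound 2 or compound 3 cannot be read, leaving the change from 4-methylphenyl to 2-chlorophenyl without a measured size. No measurement at hand explains the shift seen here.

This single step changes both the number of chlorine atoms and where they stand on the ring, so it cannot separate those two differences. From the compounds shown here alone, how a trifluoromethyl group on the phenyl ring, an amine or a longer chain would behave at this place remains open.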